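Ester alkyl variation on the shared core

The source may report more compounds than this note shows. Statements on the series, on what has been measured and on what is new or still open speak of the compounds shown alone.

Measured so far:
Compound 1 `CO/C(O)=C1\C(C)=NC(C)=C([N+](=O)[O-])C1c1ccncc1` in a functional assay (cardiac atrium) for agonist activity, with Cavia porcellus as the target (a lower number here means that less compound is needed, a higher number that more compound is needed for the effect), gives 48500 nM.
Compound 2 `CC1=NC(C)=C([N+](=O)[O-])C(c2cccnc2)/C1=C(\O)OC(C)C` in this assay gives 28500 nM.
Compound 3 `CC1=NC(C)=C([N+](=O)[O-])C(c2cccnc2)/C1=C(\O)OCC(C)C` in this assay gives 1740 nM.

Compound 1 stands at the highest of the three numbers. Compound 2 lies within the scatter of it, so no order between the two can be read; compound 3 lies well beyond the scatter and far below compound 1. Within the measured set the one change at the oxygen on the unsaturated carbon is a 16-fold lower number from compound 2 to compound 3 (1.21 log units; beyond the scatter), a large step, downward, when the chain on that oxygen grows by one carbon.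

Compound 4 `CC1=NC(C)=C([N+](=O)[O-])C(c2ccncc2)/C1=C(\O)OC1CCCC1` has not yet been measured. It differs from compound 1 as follows: cyclopentyl in place of methyl on an oxygen on an unsaturated carbon. Going by the values given here, the group on that oxygen thus goes from one heavy atom to five and brings in a five-membered non-aromatic ring; no measured pair covers a ring at this position, and none starts from methyl, so the carry-over from the measured step is loose. Among the compounds with values here, still, the only relevant precedent points downward and is large. A step of roughly that kind is expected from compound 1 to compound 4: a 14-fold lower number from compound 1 to compound 4 (1.14 log units; beyond the scatter). For compound 4 the estimate is 3500 nM, with a range from 600 nM to 20000 nM.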

Compound 4, half-maximal effective concentration: 4250 nM
The estimate for compound 4 lay 1.2-fold (0.08 log units) below the measured number; low and high end bracket the measured number.
By their numbers in this assay, from the lowest: compound 3; then compound 4; then compounds 2 and 1 (each within the scatter of the next).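

In this assay, an 11-fold lower number from compound 1 to compound 4 (1.06 log units; beyond the scatter), so a large downward step at the oxygen on the unsaturated carbon now also appears with a starting point of methyl and with an entering group that holds a five-membered non-aromatic ring of carbon only. The lower number at this position is therefore not tied to the open isobutyl chain of compound 3, and it appears in two separate pairs, compound 2 with compound 3 and compound 1 with compound 4, though these pairs differ from each other elsewhere on the core, so their steps are not set against each other here. Nothing available gives a reason for either step or bears on what the cyclopentyl group does at this place.

On these data alone, whether the step from methoxy to cyclopentyloxy follows the ring or only the carbon count stays open, and an open n-pentyl chain on the core of compound 1 would separate the two readings. The limits of the position are also undefined: neither a larger cyclohexyl ring nor a chain ending in an amine appears among these compounds, so how far the trend extends remains unknown.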